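The source may hold more compounds than are shown below. What is called first, only, known or untested is meant among the compounds shown, and "the series" means these compounds.

Measured so far:
compound 1 `O=C1C(Nc2cccc(Cl)c2)=CC(=O)c2c1nc1n2[C@H]2OC[C@@H](O)[C@H]2OC1`: 2970 nM
compound 2 `O=C1C=C(NCc2ccccc2)C(=O)c2c1nc1n2[C@H]2OC[C@@H](O)[C@H]2OC1`: > 8000 nM

In a functional assay on MCF7 cells (Homo sapiens) for inhibition, read by sulforhodamine B assay (on this read-out lower numbers stand for stronger inhibition and higher numbers for weaker inhibition), compound 1 gives 2970 nM. For compound 2 only a limit of the assay is known, > 8000 nM, so compound 2 stands at the limit of > 8000 nM in this assay, at which 1 of the 2 values shown sits, and has no number of its own. Compound 3 `O=C1C=C(Nc2ccc(C(F)(F)F)cc2)C(=O)c2c1nc1n2[C@H]2OC[C@@H](O)[C@H]2OC1` is not yet measured. It differs from compound 2 by 4-(trifluoromethyl)phenyl in place of benzyl on an amine nitrogen. Among the compounds with values here, no step between measured compounds is available; compound 1, at 2970 nM, is the nearest comparison for a ring carried on that nitrogen. Compound 3 is expected to give 4000 nM, range 1500 nM to 10000 nM. This estimate means a step of an at least 2.0-fold lower number from compound 2 to compound 3 (0.30 log units; that floor lies within the scatter) in this assay, toward stronger inhibition, though a limit again is possible.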

Compound 3, half-maximal inhibitory concentration: > 4000 nM
Compound 3 ended at the assay's limit; the forecaster's own chance of this, stated with the estimate: 30%; the middle value lies on the limit itself.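

Within the data shown here, compound 2 and compound 3 both end at limits in this assay, so no step between them can be read. The compounds shown leave open which of benzyl and 4-(trifluoromethyl)phenyl on the amine nitrogen gives stronger inhibition.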